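Swapping the Benzylamide Substituent Toward a Dimethylsulfamoyl Group

A few compounds are considered here, and "the series" means these few. Any claim that something is new, unique, unknown or untested is made for them only; others in the source may bear on it.

Compound 2, with the structure `O=C(O)C[C@H](O)C[C@H](O)CCn1c(-c2ccc(F)cc2)nc(C(=O)NCc2ccc(F)cc2)c1C1CC1`, is the reference point here. Going by the values given here, in an assay on microsomes from liver for inhibition of 3-hydroxy-3-methylglutaryl-coenzyme A reductase (Rattus norvegicus), read by scintillation counting, with stated times of 0.5 h and 0.75 h (a higher number here means a weaker inhibitor, a lower number a stronger inhibitor), compound 2 gives 3.4 nM, the lowest of the three numbers measured so far. Compound 1, `COc1ccc(CNC(=O)c2nc(-c3ccc(F)cc3)n(CC[C@@H](O)C[C@@H](O)CC(=O)O)c2C2CC2)cc1F`, carries a 3-fluoro-4-methoxyphenyl group where compound 2 has a 4-fluorophenyl, and in this assay compound 1 gives 3.7 nM; the step of a 1.1-fold lower number from compound 1 to compound 2 (0.04 log units; within the scatter), so the two compounds cannot be told apart. Compound 3, `CCc1c(C(=O)NCc2ccccc2)nc(-c2ccc(F)cc2)n1CC[C@@H](O)C[C@@H](O)CC(=O)O`, differs from compound 2 in more than one place. In this assay compound 3 gives 123 nM, a far weaker result.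

The new compound, compound 4, has the structure `CN(C)S(=O)(=O)c1ccc(CNC(=O)c2nc(-c3ccc(F)cc3)n(CC[C@@H](O)C[C@@H](O)CC(=O)O)c2C2CC2)cc1`. Among the compounds with values here, its only change from compound 2 is dimethylsulfamoyl in place of fluoro on an aromatic carbon. Within the data shown here, the one measured step that bears on this position, the step from compound 1 to compound 2, was within the scatter, which suggests the ring attached to the amide-type nitrogen tolerates variation without a large shift. On that basis the expected step is a 1.3-fold higher number from compound 2 to compound 4 (0.12 log units; within the scatter), not beyond the scatter. Compound 4 is therefore estimated at 4.5 nM in this assay, with a range from 1.5 nM to 14 nM.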

Compound 4, half-maximal inhibitory concentration: 4.9 nM
The estimate for compound 4 lay 1.1-fold (0.04 log units) below the measured number; the measured number falls inside the stated range.
By their numbers in this assay, from the lowest: compounds 2, 1 and 4 (each within the scatter of the next); then compound 3.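

In this assay, going by these compounds alone, exchanging fluoro for dimethylsulfamoyl gives a 1.4-fold higher number from compound 2 to compound 4 (0.16 log units; within the scatter) and so extends what the earlier compounds showed: there, only a small fluoro group and a 3-fluoro-4-methoxyphenyl ring had been compared, whereas here one heavy atom leaves and six enter, along with two hydrogen-bond acceptors, on an aromatic carbon para to a large group, with no shift that can be told from the scatter. The comparison with the other ring gives a 1.3-fold higher number from compound 1 to compound 4 (0.12 log units; within the scatter) and points the same way, since the 4-fluorophenyl, 3-fluoro-4-methoxyphenyl and 4-(dimethylsulfamoyl)phenyl versions cannot be told apart by their numbers here. Nothing available explains this tolerance of a much larger group.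

On these data alone, what remains open is how far the tolerance reaches, for instance whether an amine or a carboxylic acid on this aromatic carbon would keep the number in the same range. A longer chain ending in the dimethylsulfamoyl group, or an unsubstituted sulfamoyl group with its two nitrogen hydrogens, would test the same limit from another side.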